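The source may hold more compounds than are shown below. What is called first, only, known or untested is meant among the compounds shown, and "the series" means these compounds.

Compounds measured in an ADME assay on HEK293 cells (Homo sapiens) for cytotoxicity, read by MTT assay, with a stated time of 48 h; a lower number here means a stronger inhibitor, a higher number a weaker inhibitor:
- compound 1, `Cc1ccc(S(=O)(=O)/N=C(/CCNC2=CC(=O)c3ccccc3C2=O)Nc2ccccc2[N+](=O)[O-])cc1`: 69600 nM
- compound 2, `Cc1ccc(S(=O)(=O)/N=C(/CCNC2=CC(=O)c3ccccc3C2=O)Nc2ccccc2I)cc1`: 49400 nM
- compound 3, `COc1ccc(N/C(CCNC2=CC(=O)c3ccccc3C2=O)=N\S(=O)(=O)c2ccc(C)cc2)cc1OC`: 60600 nM

Compound 3 gives the second highest of the three numbers in this assay, and all three values lie within the scatter of one another. Compound 4, `COc1cc(N/C(CCNC2=CC(=O)c3ccccc3C2=O)=N\S(=O)(=O)c2ccc(C)cc2)cc(OC)c1OC`, differs from compound 3 by methoxy in place of hydrogen on an aromatic carbon, so the change reads 3,4-dimethoxyphenyl to 3,4,5-trimethoxyphenyl on the amine nitrogen.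

Among the compounds with values here, the steps that bear on this are those that alter the same aryl group: a 1.1-fold lower number from compound 1 to compound 3 (0.06 log units; within the scatter) and a 1.2-fold higher number from compound 2 to compound 3 (0.09 log units; within the scatter). Neither moves the number beyond the scatter, and the step of a 1.4-fold lower number from compound 1 to compound 2 (0.15 log units; within the scatter) on that ring is likewise flat. Adding one more methoxy is a smaller alteration than any of these, so no shift beyond the scatter is expected in this assay for compound 4, in either direction.

Compound 4 is therefore estimated at 60000 nM, with a range of 30000 nM to 120000 nM, meaning an expected step of a 1.0-fold lower number from compound 3 to compound 4 (0.00 log units; within the scatter).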

Compound 4, half-maximal inhibitory concentration: 75800 nM
Compound 4: the middle estimate sits 1.3-fold (0.10 log units) below what was measured, within the range that was stated.
By their numbers in this assay, from the lowest: compounds 2, 3, 1 and 4 (each within the scatter of the next).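

In this assay, within the data shown here, a third methoxy on the aromatic carbon ortho to a methoxy group leaves the number within the scatter (a 1.3-fold higher number from compound 3 to compound 4 (0.10 log units; within the scatter)), so this position, not varied among the earlier compounds, shows no measurable response to this change. The 3,4,5-trimethoxyphenyl group also stays within the scatter of the 2-iodophenyl group (a 1.5-fold higher number from compound 2 to compound 4 (0.19 log units; within the scatter)) and the 2-nitrophenyl group (a 1.1-fold higher number from compound 1 to compound 4 (0.04 log units; within the scatter)), which extends the flat picture on the amine nitrogen to a fourth aryl group. Nothing available explains this flatness.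

From the compounds shown here alone, whether an amine, a carboxylic acid or a longer chain at this position would move the number beyond the scatter stays open. So does the effect of any change to the shared core, since all four compounds keep it unchanged.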